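Extending the Ring Nitrogen Substituent from Methyl to Propyl

The source may report more compounds than this note shows. Statements on the series, on what has been measured and on what is new or still open speak of the compounds shown alone.

Two compounds sharing one core have been checked in an in vitro ADME assay on microsomes from liver (Homo sapiens) for pharmacokinetics; a lower number here means slower removal, a higher number faster removal of the compound. Compound 1, `Cc1ccc(S(=O)(=O)N2C=CNC(=O)[C@H]2CC(=O)NC2CCNc3ccccc32)cc1`, carries a group of 10 heavy atoms on its amide-type nitrogen. In this assay compound 1 gives < 50 mL.min-1.g-1, which is a limit of the assay rather than a number. Compound 2, `Cc1ccc(S(=O)(=O)N2C=CNC(=O)[C@H]2CC(=O)N[C@H]2CCN(C)CC2(C)C)cc1`, carries in that place a group of 9 heavy atoms with one six-membered non-aromatic ring holding one hetero atom. In this assay compound 2 gives < 14 mL.min-1.g-1, again a limit rather than a number. The step that the two limits leave unreadable from compound 1 to compound 2 cannot be read, since both values sit at limits (the limit of < 14 mL.min-1.g-1 in this assay, at which 1 of the 2 values shown sits, and (the limit of < 50 mL.min-1.g-1 in this assay, at which 1 of the 2 values shown sits)). Compound 2 thus stands at a limit that marks slow removal.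

Compound 3, `CCCN1CC[C@H](NC(=O)C[C@@H]2C(=O)NC=CN2S(=O)(=O)c2ccc(C)cc2)C(C)(C)C1`, differs from compound 2 by ethyl in place of hydrogen on a saturated chain carbon bound to an amine nitrogen in a ring; seen one bond further out, this reads methyl to propyl. Among the measured compounds shown here, no measured step touches a change of this kind, so nothing here points in a direction beyond the scatter. Compound 3 is therefore expected to give 15 mL.min-1.g-1 in this assay, between 5 mL.min-1.g-1 and 45 mL.min-1.g-1. The step this estimate means, an at least 1.0-fold higher number from compound 2 to compound 3 (0.02 log units; that floor lies within the scatter), is expected to stay within the scatter.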

Compound 3, intrinsic clearance in microsomes: < 50 mL.min-1.g-1
Compound 3: no number, only a limit (the forecaster's own chance of this, stated with the estimate: 50%); the middle value is on the limit's open side.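

Compound 2 and compound 3 both give limits in this assay rather than numbers, and the step between them cannot be read. The compounds shown leave open whether the change from methyl to propyl alters how fast the compound is removed, and if it does, in which direction and by how much.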